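Methyl to hydrogen on a chain carbon: expected bioavailability

The source may hold more compounds than are shown below. What is called first, only, known or untested is meant among the compounds shown, and "the series" means these compounds.

Measured compounds:
compound 1 `Cc1ccnc(NCc2ccc(-c3ccccc3C(=O)O)cc2)c1NC(=O)CC#N`: 19%
compound 2 `CNC(=O)c1ccccc1-c1ccc([C@@H](C)Nc2nccc(C)c2NC(=O)CC(F)(F)F)cc1`: 25%
compound 3 `COC(=O)c1ccccc1-c1ccc([C@@H](C)Nc2nccc(C)c2NC(=O)CC(F)(F)F)cc1`: 17%

In an in vivo ADME assay on the whole organism (Rattus norvegicus, strain Sprague Dawley) for pharmacokinetics (on this read-out lower numbers stand for lower oral bioavailability and higher numbers for higher oral bioavailability), compound 2 gives 25%, the highest of the three numbers, yet its nearest neighbour compound 1 sits only a number 8 percentage points lower from compound 2 to compound 3 (within the scatter) away in the other direction and compound 3 lies at a similar distance, so the three measured compounds cannot be ordered against each other. Among the compounds with values here, the only single-site step among them, a number 8 percentage points lower from compound 2 to compound 3 (within the scatter), concerns the carbonyl substituent and does not touch the site changed here.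

Compound 4 `CNC(=O)c1ccccc1-c1ccc(CNc2nccc(C)c2NC(=O)CC(F)(F)F)cc1` differs from compound 2 by hydrogen in place of methyl on a saturated chain carbon bound to an aromatic carbon and a nitrogen on an aromatic ring. Within the data shown here, no measured step covers this change. Compound 1 carries a hydrogen at the same chain carbon but also differs elsewhere, and its value of 19% is within the scatter of compound 2. The account therefore expects no step beyond the scatter from compound 2 to compound 4, an estimated change of a number 4 percentage points lower from compound 2 to compound 4 (within the scatter) in this assay.

Compound 4 is thus expected to give about 21%, with a plausible range from 8% to 38%.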

Compound 4, oral bioavailability: 79%
For compound 4 the middle estimate is 58 percentage points below the measured one; measured number outside the range, above it.
By their numbers in this assay, from the lowest: compounds 3, 1 and 2 (each within the scatter of the next); then compound 4.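

In this assay, within the data shown here, hydrogen in place of methyl on a saturated chain carbon bound to an aromatic carbon and a nitrogen on an aromatic ring gives a number 54 percentage points higher from compound 2 to compound 4 (beyond the scatter) and so marks this carbon as a site of large effect, while the only earlier single-site step, at the carbonyl carbon, is a number 8 percentage points lower from compound 2 to compound 3 (within the scatter) and gave no such sign. The change is small in count: one methyl with a single heavy atom leaves, with no ring, no hydrogen-bond donor or acceptor and no net charge involved, and that alone separates compound 4 from compound 2. Nothing measured here bears on why this one methyl matters so much.

From the compounds shown here alone, whether the same replacement would bring a similar rise with methoxy on the carbonyl carbon, or with a carboxylic acid in that place, stays open. Also open, going by these compounds, is how bioavailability would respond to an ethyl group, a fluorine atom or a cyclopropyl ring on the same chain carbon, or to the methyl in its opposite mirror-image arrangement.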